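The compounds below may be only part of what the source reports. "The series", "measured", "known", "first", "only" and "open" are said of these compounds alone.

Measured compounds:
- compound 1, `Cc1cc(OCCCCCCC[N+]2(C)CCCC2)ccc1-n1cc(C(=O)Nc2cc(F)cc(F)c2)c(=O)c2ccc(N(C)C)nc21`: "not active" (no number reported)
- compound 2, `Cc1cc(-n2cc(C(=O)Nc3cc(F)cc(F)c3)c(=O)c3ccc(N(C)C)nc32)ccc1OCCCCCCC[N+]1(C)CCCC1`: 26.1%

Two compounds of the series have been run in an assay on LX2 cells for inhibition of COL1A1 promoter (Homo sapiens), read by a luciferase reporter, with a stated time of 24 h, tested at 20 uM; on this read-out higher numbers stand for a stronger effect at the one concentration tested and lower numbers for a weaker effect. Compound 1 `Cc1cc(OCCCCCCC[N+]2(C)CCCC2)ccc1-n1cc(C(=O)Nc2cc(F)cc(F)c2)c(=O)c2ccc(N(C)C)nc21` is reported in this assay as "not active" (no number reported), without a number. Among the compounds with values here, compound 2 `Cc1cc(-n2cc(C(=O)Nc3cc(F)cc(F)c3)c(=O)c3ccc(N(C)C)nc32)ccc1OCCCCCCC[N+]1(C)CCCC1` gives 26.1% in this assay and is therefore the only entry with a number attached; it is the sole point of reference for anything further, and no step between two measured compounds can be drawn from it.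

Compound 3 `CC[N+]1(CCCCCCCOc2ccc(-n3cc(C(=O)Nc4cc(F)cc(F)c4)c(=O)c4ccc(N(C)C)nc43)cc2C)CCCC1` has not been measured. Relative to compound 2 the difference is methyl in place of hydrogen on a saturated chain carbon bound to an amine nitrogen in a ring. The change adds a single carbon to the chain already present at that place and touches nothing else in the molecule. Within the data shown here, with no measured step to lean on, the change is expected to fall within the scatter of repeated measurements of this kind, in no particular direction, so the step of a number 1.1 percentage points lower from compound 2 to compound 3 (within the scatter) is estimated as essentially flat. Compound 3 is accordingly expected to give about 25% in this assay, with a range from 10% to 42%.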

Compound 3, a percentage reported as inhibition, at one concentration (the size of the read-out at that concentration, not a potency): 44.7%
Compound 3: middle estimate off by 19.7 percentage points, on the low side, outside the stated range (above it).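

In this assay, within the data shown here, this position is not silent: methyl in place of hydrogen on a saturated chain carbon bound to an amine nitrogen in a ring gives a number 18.6 percentage points higher from compound 2 to compound 3 (beyond the scatter), a modest step and the first measured step. Cut one bond further out, the same difference reads methyl to ethyl, so adding one carbon, with no ring, no hydrogen-bond donor or acceptor and no net charge, is enough to shift the read-out while the rest of the molecule stays unchanged. Nothing at hand bears on why the read-out moves with this change.

From the compounds shown here alone, the step rests on a single pair at one concentration, so it gives no potency and no trend: whether propyl or a longer chain at the same place would extend the step, leave it flat or reverse it remains open. Also open, going by these compounds, is how a branched group such as isopropyl, or a benzyl or 2-hydroxyethyl group, would compare with ethyl there.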